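Replacing the Phenylsulfonylamino Group with Hydroxy

A few compounds are considered here, and "the series" means these few. Any claim that something is new, unique, unknown or untested is made for them only; others in the source may bear on it.

Three compounds built on one shared core have been examined in an assay on HEK293 cells for displacement of a labelled ligand from Type-2 angiotensin II receptor (Homo sapiens), tested at 10 uM; on this read-out higher numbers stand for a stronger effect at the one concentration tested and lower numbers for a weaker effect. Compound 1 `CCCCS(=O)(=O)NNC(=O)[C@@H](NC(=O)c1cccc(Cn2ccnc2)c1)[C@@H](C)CC` returned "not determined" (no result reported), so no number exists for it. Compound 2 `CC[C@H](C)[C@H](NC(=O)c1cccc(Cn2ccnc2)c1)C(=O)NNS(=O)(=O)c1ccccc1` gives 18% in this assay, and compound 3 `CC[C@H](C)[C@H](NC(=O)c1cccc(Cn2ccnc2)c1)C(=O)NNS(=O)(=O)c1ccc(OC)cc1` gives 20%. Compound 2 therefore holds the lowest of the two numbers available, with compound 3 nearest to it; the step of a number 2 percentage points higher from compound 2 to compound 3 (within the scatter) lies within the scatter, so the two compounds cannot be told apart on this read-out.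

Compound 4 `CC[C@H](C)[C@H](NC(=O)c1cccc(Cn2ccnc2)c1)C(=O)NO` has not yet been measured. It differs from compound 2 in one place: hydroxy in place of (phenylsulfonyl)amino on an amide-type nitrogen. For the measured compounds named here, the only measured step, from compound 2 to compound 3, concerns a methoxy on the aromatic ring that leaves entirely in compound 4, so it says little about this change, and no other measured pair shows what the loss of the ring and sulfur does. With both measured numbers low and close together, the expected step for compound 4 is a number 3 percentage points lower from compound 2 to compound 4 (within the scatter), which means no change beyond the scatter. Compound 4 is therefore estimated at 15%, with a range from 0% to 40%.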

Compound 4, a percentage reported as inhibition, at one concentration (the size of the read-out at that concentration, not a potency): 4%
Beside the measured number, compound 4's estimate is 11 percentage points above it, within the range that was stated.
By their numbers in this assay, from the lowest: compound 4; then compounds 2 and 3 (each within the scatter of the next).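

For the compounds shown here, replacing the (phenylsulfonyl)amino group on this amide-type nitrogen with hydroxy gives a number 14 percentage points lower from compound 2 to compound 4 (beyond the scatter) in this assay, the first step in this small set that clears the scatter. The methoxy added to the aromatic ring in compound 3 did not separate that compound from compound 2, whereas removing the whole group, with its 10 heavy atoms and its six-membered aromatic ring, does move the number, so this position responds to a change of this larger kind. Nothing shown explains the lower number, and this single swap cannot separate the loss of the ring from the loss of the sulfur or of the nitrogen.

Going by these compounds, it remains open whether a smaller group in the same place, such as an amine or a methylsulfonylamino group, would give a number like that of compound 2 or like that of compound 4. On these data alone, with compound 1 at "not determined" (no result reported), the steps that involve it cannot be read, so the effect of a chain in place of the aromatic ring on the sulfur also stays unknown.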